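From Benzyl to 4-Cyanophenyl on the Ring Carbon

The compounds below may be only part of what the source reports. "The series", "measured", "known", "first", "only" and "open" are said of these compounds alone.

Three compounds share one core and differ only at a saturated ring carbon. Compound 1 `CCCCCCCCCCCCCCCCCCNC(=O)[C@H]1CSC(CCCCCCCCCCCC)N1` gives 10700 nM in a functional assay on TSU-Pr1 cells for antiproliferative activity against TSU (Homo sapiens), read by sulforhodamine B assay; a lower number here means a stronger inhibitor, a higher number a weaker inhibitor; compound 2 `CCCCCCCCCCCCCCCCCCNC(=O)[C@H]1CSC(Cc2ccccc2)N1` gives 11200 nM; compound 3 `CCCCCCCCCCCCCCCCCCNC(=O)[C@H]1CSC(c2ccc([N+](=O)[O-])cc2)N1` gives 15900 nM. Compound 2 stands second highest of the three numbers, nearest compound 1 and furthest compound 3, all within the scatter. Compound 4 `CCCCCCCCCCCCCCCCCCNC(=O)[C@H]1CSC(c2ccc(C#N)cc2)N1` is not yet measured and differs from compound 2 by 4-cyanophenyl in place of benzyl on a saturated ring carbon. Within the data shown here, the closest precedent is a 1.4-fold higher number from compound 2 to compound 3 (0.15 log units; within the scatter), and a 1.5-fold higher number from compound 1 to compound 3 (0.17 log units; within the scatter) points the same way. Neither left the scatter, so no step beyond the scatter is expected; the step estimated is a 1.2-fold higher number from compound 2 to compound 4 (0.08 log units; within the scatter). Compound 4 is therefore expected to give 13500 nM, within 7000 nM to 26000 nM.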

Compound 4, half-maximal inhibitory concentration: > 20000 nM
Compound 4: a limit, no number; the forecaster's own chance of this, stated with the estimate: 5%; middle value at least 1.4-fold (0.17 log units) from the limit.
By their numbers in this assay, from the lowest: compounds 1, 2 and 3 (each within the scatter of the next). At a limit, above all of these: compound 4.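

Compound 4 is the only one of the four held at a limit of the assay rather than a number: the limit of > 20000 nM in this assay, at which 1 of the 4 values shown sits. The new steps are an at least 1.7-fold higher number from compound 2 to compound 4 (0.25 log units; that floor lies within the scatter), an at least 1.2-fold higher number from compound 3 to compound 4 (0.09 log units; that floor lies within the scatter) and an at least 1.8-fold higher number from compound 1 to compound 4 (0.27 log units; that floor lies within the scatter). Each is only a floor, so this position has given a first reading with no upper bound, yet no change here is shown to leave the scatter.

From the compounds shown here alone, how far the true value of compound 4 lies from its limit stays open. So does whether an amine or a carboxylic acid in place of cyano would give a step beyond the scatter.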